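The compounds below may be only part of what the source reports. "The series", "measured", "known", "first", "only" and "open" are said of these compounds alone.

Compound 1 `CCOc1ccc(-n2nncc2CN2C(=O)C3(C(C#N)=C(N)Oc4c(N)cc5nc6ccccc6nc5c43)c3ccccc32)cc1` gives 26800 nM in a functional assay on MCF7 cells (Homo sapiens) for antiproliferative activity, read by MTT assay, with a stated time of 48 h; on this read-out lower numbers stand for stronger inhibition and higher numbers for weaker inhibition.
Compound 2 `Cc1ccc(-n2nncc2CN2C(=O)C3(C(C#N)=C(N)Oc4c(N)cc5nc6ccccc6nc5c43)c3ccccc32)cc1Cl` reaches only the limit of > 50000 nM in this assay.
Compound 3 `Cc1cc(C)c(-n2nncc2CN2C(=O)C3(C(C#N)=C(N)Oc4c(N)cc5nc6ccccc6nc5c43)c3ccccc32)c(C)c1` likewise reaches only the limit of > 50000 nM in this assay.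

Compound 3 therefore stands at the limit, with no number of its own; two of the three values sit there (the limit of > 50000 nM in this assay, at which 2 of the 3 values shown sit). Compound 4 `COc1cc(-n2nncc2CN2C(=O)C3(C(C#N)=C(N)Oc4c(N)cc5nc6ccccc6nc5c43)c3ccccc32)c(OC)cc1Cl` differs from compound 3 by 4-chloro-2,5-dimethoxyphenyl in place of 2,4,6-trimethylphenyl on an aromatic nitrogen. Among the measured compounds shown here, no measured step covers this pair directly. The steps of an at least 1.8-fold higher number from compound 1 to compound 2 (0.27 log units; that floor lies within the scatter) and an at least 1.8-fold higher number from compound 1 to compound 3 (0.27 log units; that floor lies within the scatter) both run from a number up to the limit, and the step that the two limits leave unreadable from compound 2 to compound 3 cannot be read. Since every aryl exchange so far ends at the limit, the step of an at least 1.1-fold lower number from compound 3 to compound 4 (0.04 log units; that floor lies within the scatter) is expected to be small, with a real chance of another limit. Compound 4 is estimated at 45000 nM, between 20000 nM and 100000 nM.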

Compound 4, half-maximal inhibitory concentration: > 50000 nM
Compound 4: no number, only a limit; the forecaster's own chance of this, stated with the estimate: 60%; middle value at least 1.1-fold (0.04 log units) from the limit.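

In this assay compound 4 gives only a limit, > 50000 nM. Replacing 4-ethoxyphenyl with 4-chloro-2,5-dimethoxyphenyl on this aromatic nitrogen gives an at least 1.8-fold higher number from compound 1 to compound 4 (0.27 log units; that floor lies within the scatter), so a group with hydrogen-bond acceptors also fails to yield a number, and compound 1 remains the only exception. The steps among compound 2, compound 3 and compound 4 cannot be read, and most values now sit at one limit: the limit of > 50000 nM in this assay, at which 3 of the 4 values shown sit.

On these data alone, how compound 2, compound 3 and compound 4 actually rank stays open. Also open, as far as these compounds go, is whether a phenyl group carrying an amine or a carboxylic acid would give a number at this position.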